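The compounds below may be only part of what the source reports. "The series", "measured", "known", "first", "only" and "open" are said of these compounds alone.

Measured in a functional assay on DU-145 cells (Homo sapiens) for cytotoxicity, read by trypan blue exclusion, with a stated time of 96 h; a lower number here means a stronger inhibitor, a higher number a weaker inhibitor:
- Compound 1 `COc1ccc(CS(=O)(=O)/C=C/c2c(OC)cccc2OC)cc1[N+](=O)[O-]`: 20000 nM
- Compound 2 `COc1cc(OC)c(/C=C/S(=O)(=O)Cc2ccc(F)c([N+](=O)[O-])c2)c(OC)c1`: 25000 nM
- Compound 3 `COC(=O)C(F)(F)Nc1cc(CS(=O)(=O)/C=C/c2c(OC)cc(OC)cc2OC)ccc1OC`: 250 nM

Compound 3 is the strongest inhibitor of the three, and its gaps to compound 1 and compound 2 both lie well beyond the usual scatter. Compound 4 `COc1cc(OC)c(/C=C/S(=O)(=O)Cc2ccc(OC)c(NC(F)(F)C(=O)O)c2)c(OC)c1` has not yet been measured. It differs from compound 3 by one small change: hydrogen in place of methyl on an oxygen next to a carbonyl group. This puts hydrogen in place of methyl on an oxygen next to a carbonyl group, turning methoxycarbonyl to carboxy. Within the data shown here, no measured pair shows this change, so the expectation rests only on compound 3 at 250 nM and remains loose. The expected step is a 1.7-fold lower number from compound 3 to compound 4 (0.22 log units; within the scatter), which is no shift beyond the scatter. For compound 4 the estimate is 150 nM, with an expected range of 30 nM to 1000 nM.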

Compound 4, half-maximal inhibitory concentration: 150 nM
For compound 4 middle estimate and measured number coincide at the digits printed; measured number inside the range.
By their numbers in this assay, from the lowest: compounds 4 and 3 (each within the scatter of the next); then compounds 1 and 2 (each within the scatter of the next).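

In this assay, replacing methoxycarbonyl with carboxy gives a 1.7-fold lower number from compound 3 to compound 4 (0.22 log units; within the scatter). The methyl on an oxygen next to a carbonyl group can therefore give way to hydrogen with no shift this measurement can distinguish, so the number does not depend on that methyl. No measurement at hand explains why the two compounds read alike.

From the compounds shown here alone, how an amide or a hydroxymethyl group would read in place of the carboxy remains open. So does what a longer chain would do there, and whether the two fluorines matter to the number.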